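This account rests on a few compounds, and the source may have more. Where it says the series, first, only, none or still open, it means among the compounds named here.

Measured compounds:
- compound 1 `O=C1c2cccc(O)c2C(=O)C1(O)O`: > 100000 nM
- compound 2 `Cc1cccc2c1C(=O)C(O)(O)C2=O`: > 100000 nM

In an assay on isolated protein for inhibition of carbonic anhydrase 4 (Homo sapiens), read by stopped-flow, with a stated time of 15 min (a higher number here means a weaker inhibitor, a lower number a stronger inhibitor), compound 2 gives > 100000 nM, which is a limit of the assay rather than a number. Compound 1 likewise gives a limit, > 100000 nM. On these data alone, the step from compound 1 to compound 2 is a step that the two limits leave unreadable from compound 1 to compound 2, so its size is unknown. Compound 3 `O=C1c2cccc([N+](=O)[O-])c2C(=O)C1(O)O` differs from compound 2 by nitro in place of methyl on an aromatic carbon. Among the measured compounds shown here, the only measured step bearing on this change is that unreadable one; because of the limit of > 100000 nM in this assay, at which 2 of the 2 values shown sit, no direction can be read, and no step beyond the scatter is assumed. Compound 3 is therefore expected at 150000 nM, between 40000 nM and 600000 nM, an estimated step that the limit leaves unreadable from compound 2 to compound 3.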

Compound 3, inhibition constant: > 100000 nM
Compound 3: only a limit was reported (the forecaster's own chance of this, stated with the estimate: 85%); the middle value does not contradict the limit.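

Among the compounds shown here, no step between compound 1, compound 2 and compound 3 can be read, because each result is only a limit: the limit of > 100000 nM in this assay, at which 3 of the 3 values shown sit. On these data alone, whether hydroxy, methyl or nitro on the aromatic carbon changes inhibition stays open.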